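This account rests on a few compounds, and the source may have more. Where it says the series, first, only, none or still open, it means among the compounds named here.

Compound 1 `O=C(O)C1=Cc2ccccc2OC1(OCc1cc(-c2ccc([N+](=O)[O-])cc2)no1)C(F)(F)F`: > 150000 nM
Compound 2 `CCOC(=O)C1=Cc2ccccc2OC1(OCc1cc(-c2cccc(C(F)(F)F)c2)no1)C(F)(F)F`: 48600 nM
Compound 3 `O=C(O)C1=Cc2ccccc2OC1(OCc1cc(-c2ccc3ccccc3c2)no1)C(F)(F)F`: > 150000 nM

The three measured compounds share one core and differ in the aryl group hung on the five-membered aromatic ring and in whether the chain ends as a free acid or an ethyl ester. In a functional assay on A549 cells (Homo sapiens) for inhibition, read by MTT assay, with a stated time of 24 h (a lower number here means a stronger inhibitor, a higher number a weaker inhibitor), compound 1 reaches only a limit, > 150000 nM. Compound 3 likewise reaches only a limit, > 150000 nM. Among the measured compounds shown here, compound 2, the ethyl ester, is the one compound with a number, giving 48600 nM. The step that the two limits leave unreadable from compound 1 to compound 3 cannot be sized, since both of its values sit at the limit of > 150000 nM in this assay, at which 2 of the 3 values shown sit.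

Compound 4 `O=C(O)C1=Cc2ccccc2OC1(OCc1cc(-c2cccc(C(F)(F)F)c2)no1)C(F)(F)F` keeps the free acid of compound 3 and makes the change (3-(trifluoromethyl)phenyl in place of naphthalen-2-yl on an aromatic carbon). For the measured compounds named here, the only measured step touching this part of the molecule is unreadable, so it gives no direction; what the data show is that both acids sit at the limit while the sole number belongs to an ester. Compound 4 is therefore expected to remain near the limit, estimated at 150000 nM, with a range from 60000 nM to 350000 nM. The expected step of a number no higher from compound 3 to compound 4 (the limit leaves the size open) is accordingly no change beyond the scatter.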

Compound 4, half-maximal inhibitory concentration: > 150000 nM
Compound 4: only a limit was reported; the forecaster's own chance of this, stated with the estimate: 65%; the middle value lies on the limit itself.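

Compound 2 and compound 4 differ only at the end of the chain, so this pair shows the effect of that change with the aryl group held constant: replacing the ethyl of the ester with hydrogen gives an at least 3.0-fold higher number from compound 2 to compound 4 (0.48 log units; beyond the scatter) in this assay. The 3-(trifluoromethyl)phenyl group, like 4-nitrophenyl and naphthalen-2-yl, therefore leaves the free acid at the limit. The steps among compound 1, compound 3 and compound 4 cannot be read, because all three sit at the same limit: the limit of > 150000 nM in this assay, at which 3 of the 4 values shown sit.

Going by these compounds, it remains open whether the aryl group matters at all once the chain ends in an ethyl ester, as only one such ester appears here. A methyl ester or a primary amide in place of the ethyl ester also remains untested among the compounds shown.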